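Swapping Nitrile for Nitro on Two Antiproliferative Scaffolds

This account rests on a few compounds, and the source may have more. Where it says the series, first, only, none or still open, it means among the compounds named here.

Compound 1, `CC(O)(COc1ccc(S(F)(F)(F)(F)F)cc1)C(=O)Nc1ccc(C#N)c(C(F)(F)F)c1`, in a functional assay on DU-145 cells (Homo sapiens) for antiproliferative activity, read by propidium iodide staining, with a stated time of 96 h (a higher number here means a weaker inhibitor, a lower number a stronger inhibitor), gives 25500 nM.
Compound 2, `CC(O)(COc1ccc(S(F)(F)(F)(F)F)cc1)C(=O)Nc1ccc([N+](=O)[O-])c(C(F)(F)F)c1`, gives 21200 nM.
Compound 3, `CC1(C)C(=O)N(c2ccc(C#N)cc2C(F)(F)F)C(=S)N1c1ccc(S(F)(F)(F)(F)F)cc1`, gives 12700 nM.

The three measured values lie within the usual scatter of one another. Compound 1 and compound 2 share one core, and the change between them is nitro in place of cyano on an aromatic carbon; it made a 1.2-fold lower number from compound 1 to compound 2 (0.08 log units; within the scatter). Compound 3 carries a different core; the difference between the two cores is not broken down here.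

Compound 4, `CC1(C)C(=O)N(c2ccc([N+](=O)[O-])cc2C(F)(F)F)C(=S)N1c1ccc(S(F)(F)(F)(F)F)cc1`, is still to be measured. It differs from compound 3 by nitro in place of cyano on an aromatic carbon, the same kind of change as from compound 1 to compound 2, though here the group sits meta to a trifluoromethyl group rather than ortho to it. Resting on the small step seen from compound 1 to compound 2, the change from compound 3 to compound 4 is expected to be about a 1.2-fold lower number from compound 3 to compound 4 (0.08 log units; within the scatter). Compound 4 is therefore estimated at 10500 nM, most likely between 5000 nM and 25000 nM.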

Compound 4, half-maximal inhibitory concentration: 100000 nM
Beside the measured number, compound 4's estimate is 9.5-fold (0.98 log units) below it, outside the stated range (above it).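

Replacing the nitrile with nitro on the core of compound 3 gave a 7.9-fold higher number from compound 3 to compound 4 (0.90 log units; beyond the scatter) in this assay, so a swap that changed little on the core of compound 1 came with a clear loss of activity here. Set side by side, the two steps differ, which means that in this series the result of this swap on one core cannot simply be carried over to the other: the same change on two cores in this assay, a 1.2-fold lower number (0.08 log units; within the scatter) from compound 1 to compound 2 and a 7.9-fold higher number (0.90 log units; beyond the scatter) from compound 3 to compound 4, 9.5-fold (0.98 log units) apart, beyond the scatter of two such steps. Among the compounds shown here, this does not show why the outcomes part, since the cores differ in more than one place and each offers only a single pair, nor does it predict how the swap would behave on any further core.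

The compounds shown leave open whether another group in the same place, such as an amine or a carboxylic acid, would also give different results on the two cores. They also leave open whether the gap between the cores would persist with a methyl group in place of the trifluoromethyl group.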